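The source may hold more compounds than are shown below. What is called first, only, known or untested is meant among the compounds shown, and "the series" means these compounds.

Measured compounds:
compound 1 `O=C(O)Cc1sc(C(c2ccc(F)cc2)c2ccc(F)cc2)nc1-c1ccnc(N2CCCC2)c1` — 80%
compound 2 `O=C(O)Cc1sc(NCc2ccccc2)nc1-c1ccc(Cl)cc1` — 30%

In an in vitro functional assay on HEK285-7 cells for antagonist activity at prostaglandin D2 receptor 2 (Homo sapiens), read by BRET and beta-arrestin recruitment (a lower number here means a smaller maximal response, a higher number a larger maximal response), compound 1 gives 80%, the highest of the two numbers available. Compound 2 gives 30%, which lies well below compound 1, a gap beyond the usual scatter; as the two structures differ in more than one place, no single step can be read from them. Compound 3 `O=C(O)Cc1sc(C(c2ccc(F)cc2)c2ccc(F)cc2)nc1-c1cc(F)cc(F)c1` has not been measured. It differs from compound 1 in one place: 3,5-difluorophenyl in place of 2-(pyrrolidin-1-yl)pyridin-4-yl on an aromatic carbon. Among the compounds with values here, with no step between closely related compounds to lean on, the size of the expected change is uncertain. Within the data shown here, compound 3 is expected to fall somewhat below compound 1, an estimated step of a number 15 percentage points lower from compound 1 to compound 3 (beyond the scatter), since compound 1 stands at 80% and the only other value, that of compound 2, is far lower. Compound 3 is therefore estimated at 65%, with a likely range from 40% to 90%.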

Compound 3, largest response reached (reported as efficacy), in percent of the reference or control that the assay uses: 80%
Estimate against measurement, compound 3: 15 percentage points below, within the range that was stated.
By their numbers in this assay, from the lowest: compound 2; then compounds 1 and 3 (each within the scatter of the next).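

In this assay, putting 3,5-difluorophenyl in place of 2-(pyrrolidin-1-yl)pyridin-4-yl on the aromatic carbon next to the ring nitrogen gives no change at the digits printed from compound 1 to compound 3 (within the scatter). Within the data shown here, this is the first single-place comparison at this position, and it shows that the maximal response holds when a carbon-only aromatic ring with two fluorines replaces a group with a pyrrolidine ring and two hydrogen-bond acceptors. Nothing available explains why the response stays the same.

From the compounds shown here alone, whether the response would also hold with a morpholine or an unsubstituted phenyl at this position remains open. The compounds shown also leave open which change separates compound 2 from the others, as it differs from them in more than one place.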